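A Methyl Added Where Earlier It Changed Little

The compounds below may be only part of what the source reports. "The series", "measured", "known", "first", "only" and "open" are said of these compounds alone.

Compound 1 `Cn1c2c(c3ccccc3c1=O)CCOc1ccccc1-2` and compound 2 `Cc1ccc2c(=O)n(C)c3c(c2c1)CCOc1ccccc1-3` share one core, while compound 3 `C=COc1ccccc1-c1c(Br)c2ccccc2c(=O)n1Cc1ccc(OC)cc1` is built on a different core; the difference between the two cores is not broken down here. In a functional assay on HL-60 cells (Homo sapiens) for cytotoxicity, read by sulforhodamine B assay (a lower number here means a stronger inhibitor, a higher number a weaker inhibitor), compound 1 gives 37600 nM, and compound 2 gives 33600 nM. Compound 3 gives 59500 nM in this assay. Compound 2 differs from compound 1 by methyl in place of hydrogen on an aromatic carbon, and this change produced a 1.1-fold lower number from compound 1 to compound 2 (0.05 log units; within the scatter).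

Compound 4 `C=COc1ccccc1-c1c(Br)c2cc(C)ccc2c(=O)n1Cc1ccc(OC)cc1` has not yet been measured. It differs from compound 3 by methyl in place of hydrogen on an aromatic carbon. Going by the values given here, this is the same kind of change as the one from compound 1 to compound 2: in both, a methyl enters on an aromatic carbon of a six-membered aromatic ring of carbon only, meta to a fused ring and para to a fused ring. The surroundings differ in one point: in compound 2 that ring is part of a fused or bridged system of four rings, whereas in compound 4 it is part of a fused or bridged system of two rings.

Because a 1.1-fold lower number from compound 1 to compound 2 (0.05 log units; within the scatter) lay within the scatter, the same kind of change is expected to move the number of compound 4 little away from that of compound 3. The expected step is a 1.1-fold lower number from compound 3 to compound 4 (0.03 log units; within the scatter). Compound 4 is estimated at 55000 nM, with a likely range from 25000 nM to 120000 nM.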

Compound 4, half-maximal inhibitory concentration: 29200 nM
Estimate against measurement, compound 4: 1.9-fold (0.27 log units) above; the measured number falls inside the stated range.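

In this assay, the methyl in place of hydrogen on an aromatic carbon gave a 2.0-fold lower number from compound 3 to compound 4 (0.31 log units; beyond the scatter), a modest step that only just clears the usual scatter of repeated measurements. Set beside the same change on the other core, the two results cannot be told apart: the same change on two cores in this assay, a 1.1-fold lower number (0.05 log units; within the scatter) from compound 1 to compound 2 and a 2.0-fold lower number (0.31 log units; beyond the scatter) from compound 3 to compound 4, 1.8-fold (0.26 log units) apart, within the scatter of two such steps. This shows that, in these two pairs, the change carries from the core of compound 1 to the core of compound 3 without a measurable difference between the cores, but it does not show that the two cores truly respond alike, since a real difference smaller than the scatter would go unseen and two pairs say nothing about any further core.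

The compounds shown leave open whether a longer chain such as ethyl, or a group of another kind such as an amine or a carboxylic acid, on this same aromatic carbon would move the number further than methyl does. They also leave open whether such a group would give steps of similar size on both cores, which would be a stronger test of how well a change carries across this series.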